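The source may report more compounds than this note shows. Statements on the series, on what has been measured and on what is new or still open speak of the compounds shown alone.

The measured compounds are:

compound 1, `CN(C)CCCOc1ccc(-c2nc3ccc(Oc4ccc(Cl)cc4)cc3o2)cc1`, which in an assay on isolated protein for inhibition of advanced glycosylation end product-specific receptor (Homo sapiens), read by FRET, with stated times of 30 min and 1 h, tested at 4 uM (a lower number here means less inhibition, a higher number more inhibition at the concentration tested (going by the name of the read-out)), gives 4.9%
compound 2, `Clc1ccc(Oc2ccc3nc(-c4ccc(OCCCN5CCCCC5)cc4)oc3c2)cc1`, which in this assay gives 2.2%

Compound 2 stands lowest of the two numbers, and its nearest neighbour is compound 1, but the step of a number 2.7 percentage points lower from compound 1 to compound 2 (within the scatter) is within the scatter, so the two values cannot be told apart. Compound 3 is `CC(C)(C)C1CCN(CCCOc2ccc(-c3nc4ccc(Oc5ccc(Cl)cc5)cc4o3)cc2)CC1`. It differs from compound 2 by tert-butyl in place of hydrogen on a saturated ring carbon. Among the measured compounds shown here, the only measured step that bears on this change is the one from compound 1 to compound 2, which also altered the amine group at the end of the same chain, and that step was a number 2.7 percentage points lower from compound 1 to compound 2 (within the scatter), within the scatter. Nothing measured here points to a change beyond the scatter in this assay when the ring carbon of that amine is substituted. Compound 3 is therefore expected to give about 4% in this assay, with a range from -5% to 14%, and the estimated step of a number 1.8 percentage points higher from compound 2 to compound 3 (within the scatter) is expected to stay within the scatter.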

Compound 3, a percentage reported as inhibition, at one concentration (the size of the read-out at that concentration, not a potency): 16.6%
The estimate for compound 3 lay 12.6 percentage points below the measured number, and the stated range ends below it.
By their numbers in this assay, from the lowest: compounds 2 and 1 (each within the scatter of the next); then compound 3.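

In this assay, among the compounds shown here, the ring carbon three ring bonds from the ring nitrogen of the piperidin-1-yl group proves to be a place where a substituent can shift the read-out: tert-butyl in place of hydrogen there gives a number 14.4 percentage points higher from compound 2 to compound 3 (beyond the scatter), the first step in this small set to clear the scatter, though it remains modest. The replacement of dimethylamino by 4-(tert-butyl)piperidin-1-yl at the end of the same chain gives a number 11.7 percentage points higher from compound 1 to compound 3 (beyond the scatter), whereas the replacement by unsubstituted piperidin-1-yl gave only a number 2.7 percentage points lower from compound 1 to compound 2 (within the scatter), so among these three compounds the rise appears only when tert-butyl is present. What lies behind this rise cannot be said from the information available here.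

The compounds shown leave open whether the rise is tied to tert-butyl itself or whether a methyl or a hydroxyl group on that same ring carbon would give a similar number. They also leave open whether 4-(tert-butyl)piperidin-1-yl would hold this number on a longer chain, and, as the read-out comes from a single concentration, they give no potency for any of the three compounds.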